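Six-membered to five-membered ring on the amide carbonyl

The source may hold more compounds than are shown below. What is called first, only, known or untested is meant among the compounds shown, and "the series" means these compounds.

Measured compounds, read in a functional assay on A549 cells (Homo sapiens) for antiproliferative activity, read by MTT assay, with a stated time of 72 h; on this read-out higher numbers stand for weaker inhibition and lower numbers for stronger inhibition:
- compound 1, `COc1cc(F)c(NC(=O)c2ccncc2OC)cc1Nc1nccc(-c2cn(C)c3ccccc23)n1`, gives 3430 nM
- compound 2, `COc1cc(F)c(NC(=O)c2ccccn2)cc1Nc1nccc(-c2cn(C)c3ccccc23)n1`, gives 7980 nM
- compound 3, `COc1cc(F)c(NC(=O)c2ncccn2)cc1Nc1nccc(-c2cn(C)c3ccccc23)n1`, gives 8400 nM

Compound 3 stands at the highest number of the three, but its gap to compound 2 is within the scatter, so the two cannot be ordered; only compound 1 sits clearly apart, the step of a 2.4-fold higher number from compound 1 to compound 3 (0.39 log units; beyond the scatter) lying beyond the scatter, as does a 2.3-fold higher number from compound 1 to compound 2 (0.37 log units; beyond the scatter).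

Compound 4, `COc1cc(F)c(NC(=O)c2nccn2C)cc1Nc1nccc(-c2cn(C)c3ccccc23)n1`, differs from compound 3 in one place: 1-methyl-1H-imidazol-2-yl in place of pyrimidin-2-yl on a carbonyl carbon. The closest measured step is the exchange of one six-membered ring for another on the same carbonyl carbon, a 1.1-fold higher number from compound 2 to compound 3 (0.02 log units; within the scatter), which is within the scatter. Within the data shown here, no measured step exchanges a six-membered ring for a five-membered one, so the series offers no direct guide for that part of the change. Given that the two ring swaps on this carbonyl that keep the unsubstituted heteroaryl hardly move the number, compound 4 is expected to stay close to compound 3, with the step of a 1.2-fold lower number from compound 3 to compound 4 (0.08 log units; within the scatter) expected to be small. The estimate for compound 4 is 7000 nM, with a range from 2500 nM to 20000 nM.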

Compound 4, half-maximal inhibitory concentration: 5140 nM
Compound 4: middle estimate off by 1.4-fold (0.13 log units), on the high side, within the range that was stated.
By their numbers in this assay, from the lowest: compounds 1, 4, 2 and 3 (each within the scatter of the next, the first and the last beyond it).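

In this assay, replacing a six-membered aromatic ring with a five-membered one on this carbonyl carbon gives no readable change (a 1.6-fold lower number from compound 3 to compound 4 (0.21 log units; within the scatter)) and (a 1.6-fold lower number from compound 2 to compound 4 (0.19 log units; within the scatter)), as both steps lie within the scatter. Compound 4 also cannot be separated from the 3-methoxypyridin-4-yl amide (a 1.5-fold higher number from compound 1 to compound 4 (0.18 log units; within the scatter)), so it fills the gap between compound 1 and compounds 2 and 3, although those two remain beyond the scatter from compound 1. No measurement available here bears on why this ring exchange leaves the number within the scatter.

From the compounds shown here alone, the five-membered ring is represented only by 1-methyl-1H-imidazol-2-yl, so the contribution of its methyl group stays open. Also open, going by these compounds, is what an unmethylated imidazol-2-yl, a thiazol-2-yl or a pyridine carrying a dimethylamino group would give on this carbonyl carbon.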